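Ethynyl in Place of Thiophen-2-yl on the Shared Core

The source may hold more compounds than are shown below. What is called first, only, known or untested is meant among the compounds shown, and "the series" means these compounds.

Compound 1 `COc1ncnc2c1c(-c1cccs1)cn2[C@@H]1O[C@H](CO)[C@@H](O)[C@H]1O`: 1760 nM
Compound 2 `CSc1ncnc2c1c(-c1cccs1)cn2[C@@H]1O[C@H](CO)[C@@H](O)[C@H]1O`: 1960 nM

In a functional assay on HeLa S3 cells (Homo sapiens) for antiproliferative activity, read by XTT assay, with a stated time of 72 h (on this read-out lower numbers stand for stronger inhibition and higher numbers for weaker inhibition), compound 1 gives 1760 nM and compound 2 gives 1960 nM. The step of a 1.1-fold higher number from compound 1 to compound 2 (0.05 log units; within the scatter) lies within the scatter, so compound 1 stands on the lower of two numbers that cannot be told apart. Compound 3 `C#Cc1cn([C@@H]2O[C@H](CO)[C@@H](O)[C@H]2O)c2ncnc(OC)c12` differs from compound 1 by ethynyl in place of thiophen-2-yl on an aromatic carbon. Among the compounds with values here, no measured step touches this group on the core: the only known step concerns methoxy and methylsulfanyl elsewhere and gives no guidance here. Compound 3 is therefore expected to give 1500 nM (range 300 nM to 7000 nM), an estimated step of a 1.2-fold lower number from compound 1 to compound 3 (0.07 log units; within the scatter) with no direction supported beyond the scatter.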

Compound 3, half-maximal inhibitory concentration: 1730 nM
Compound 3: the middle estimate sits 1.2-fold (0.06 log units) below what was measured, and the stated range covers the measured number.
By their numbers in this assay, from the lowest: compounds 3, 1 and 2 (each within the scatter of the next).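

The step of a 1.0-fold lower number from compound 1 to compound 3 (0.01 log units; within the scatter) in this assay comes with ethynyl in place of thiophen-2-yl, so at this aromatic carbon a five-membered aromatic ring gives way to a group with no ring and the number stays within the scatter. The earlier step concerned only methoxy and methylsulfanyl and said nothing about this position. On these data alone, whether an amine or a longer chain here would move the number beyond the scatter remains open, as does whether methylsulfanyl in place of methoxy reads the same with ethynyl on the shared core. No measurement at hand bears on why these two groups read alike.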